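Clearance in Mice: Swapping Piperidine for Piperazine

The source may hold more compounds than are shown below. What is called first, only, known or untested is meant among the compounds shown, and "the series" means these compounds.

Measured in an ADME assay on microsomes from liver (Mus musculus) for metabolic stability, read by LC-MS, using NADPH, with stated times of 10 min and 30 min, tested at 1 uM (on this read-out higher numbers stand for fast clearance and lower numbers for slow clearance), so far
Compound 1 `COC(=O)C1=C(C)NC(c2nccs2)=NC1(C)c1ccc(S(C)(=O)=O)cc1` gives 57 mL/min/kg
Compound 2 `COC(=O)C1=C(C)NC(c2nccs2)=NC1(C)c1ccc(F)c(F)c1` gives 83 mL/min/kg
Compound 3 `COC(=O)C1=C(CN2CCCCC2)NC(c2nccs2)=NC1(C)c1ccc(F)cc1` gives 88 mL/min/kg

Compound 3 stands within the usual scatter of both other compounds, so these three results cannot be reliably ranked. The next compound, compound 4 `COC(=O)C1=C(CN2CCNCC2)NC(c2nccs2)=NC1(C)c1ccc(F)cc1`, has one change from compound 3, with piperazin-1-yl in place of piperidin-1-yl on a saturated chain carbon bound to a double-bonded ring carbon. Among the measured compounds shown here, no two measured compounds differ in only one place, so nothing here directly shows how large this swap's effect will be. In this assay a small downward shift that stays inside the scatter is expected. This expectation rests only on the narrow spread so far, with compound 1 at 57 mL/min/kg and compound 2 at 83 mL/min/kg both within the scatter of compound 3. The estimated change is a 1.3-fold lower number from compound 3 to compound 4 (0.10 log units; within the scatter) overall. Compound 4 is expected to give 70 mL/min/kg, with an estimated range from 40 mL/min/kg to 105 mL/min/kg in this test.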

Compound 4, clearance: 39 mL/min/kg
For compound 4 the middle estimate is 1.8-fold (0.25 log units) above the measured one; measured number below the stated range.
By their numbers in this assay, from the lowest: compounds 4, 1, 2 and 3 (each within the scatter of the next, the first and the last beyond it).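

In this assay, among the compounds shown here, the first pair of compounds that differ in only one place gives a 2.3-fold lower number from compound 3 to compound 4 (0.35 log units; beyond the scatter), so the group on this saturated chain carbon bound to a double-bonded ring carbon can shift clearance beyond the usual scatter. The change is small on paper: both groups are six-membered non-aromatic rings with the same number of heavy atoms, but piperazin-1-yl has one more ring nitrogen and adds a hydrogen-bond donor. No measurement here explains the lower number.

As far as these compounds go, it remains open whether the second nitrogen or its hydrogen-bond donor matters more, and morpholin-4-yl or 4-methylpiperazin-1-yl at this place could help separate the two. Whether this swap would give a similar step on a different parent compound is also unknown.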